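Phenoxy replacement on the diaryl piperidine ether series

The compounds below may be only part of what the source reports. "The series", "measured", "known", "first", "only" and "open" are said of these compounds alone.

Compound 3 `COc1cc(OCCCN2CCC(C(c3ccc(F)cc3)c3ccc(F)cc3)CC2)ccc1C(C)=O` gives 3.16 nM in a functional assay (aorta) with Oryctolagus cuniculus as the target (on this read-out lower numbers stand for tighter binding and higher numbers for weaker binding), and holds the lowest number of the three measured. Compound 2 `COc1cc(C(C)O)ccc1OCCCN1CCC(C(c2ccc(F)cc2)c2ccc(F)cc2)CC1` gives 10 nM in this assay, and compound 1 `COc1cc(C(C)=O)ccc1OCCCN1CCC(C(c2ccc(F)cc2F)c2ccc(F)cc2F)CC1` gives 15.9 nM. Compound 4 `CC(=O)Nc1ccc(OCCCN2CCC(C(c3ccc(F)cc3)c3ccc(F)cc3)CC2)cc1` is the next variant, differing from compound 3 by 4-acetamidophenyl in place of 4-acetyl-3-methoxyphenyl on an oxygen on a saturated carbon. For the measured compounds named here, the only measured step touching this position is a 3.2-fold lower number from compound 2 to compound 3 (0.50 log units; beyond the scatter), which shows that altering substituents on this phenyl ring moves the read-out by a modest margin. Going by the values given here, no step removes the methoxy group or introduces an amide, so the direction is uncertain; a modest rise is expected, a 2.5-fold higher number from compound 3 to compound 4 (0.40 log units; beyond the scatter). Compound 4 is thus estimated at 8 nM, within 2.5 nM to 25 nM.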

Compound 4, dissociation constant: 12.6 nM
The estimate for compound 4 lay 1.6-fold (0.20 log units) below the measured number; low and high end bracket the measured number.
By their numbers in this assay, from the lowest: compound 3; then compounds 2, 4 and 1 (each within the scatter of the next).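

In this assay, 4-acetamidophenyl in place of 4-acetyl-3-methoxyphenyl gives a 4.0-fold higher number from compound 3 to compound 4 (0.60 log units; beyond the scatter), so the 4-acetyl-3-methoxyphenyl of compound 3 now stands out against two different groups at this position. The same group in place of 4-(1-hydroxyethyl)-2-methoxyphenyl gives a 1.3-fold higher number from compound 2 to compound 4 (0.10 log units; within the scatter), which leaves these two groups unresolved on this read-out. Nothing available on this change accounts for the step.

On these data alone, the change alters the acetyl, the methoxy and the amide together, so their separate shares stay open. Also open, as far as these compounds go, is how an amine or a carboxylic acid would read in place of the acetamido group.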